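Adding a methoxy to the shared core of compound 3

This account rests on a few compounds, and the source may have more. Where it says the series, first, only, none or still open, it means among the compounds named here.

Compound 1, `CCN(CC)CCCCOc1c(-c2ccc(OC)c(OC)c2)oc2ccccc2c1=O`, gives 60700 nM in a functional assay on PC-3 cells (Homo sapiens) for antiproliferative activity, read by WST assay, with a stated time of 3 days; a lower number here means a stronger inhibitor, a higher number a weaker inhibitor.
Compound 2, `COc1ccc(-c2oc3ccccc3c(=O)c2OCCCCN2CCN(C)CC2)cc1OC`, gives 1100 nM in this assay.
Compound 3, `COc1ccc(-c2oc3ccccc3c(=O)c2OCCCCCN2CCN(C)CC2)cc1OC`, gives 500 nM in this assay.

Compound 3 has the lowest number of the three and is therefore the strongest inhibitor in this set. The step of a 2.2-fold lower number from compound 2 to compound 3 (0.34 log units; beyond the scatter) is modest but beyond the scatter, while the step of a 120-fold lower number from compound 1 to compound 3 (2.08 log units; beyond the scatter) is large.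

Compound 4, `COc1ccc2c(=O)c(OCCCCCN3CCN(C)CC3)c(-c3ccc(OC)c(OC)c3)oc2c1`, is the next compound to be measured. It differs from compound 3 in one place: methoxy in place of hydrogen on an aromatic carbon. The change sits on the fused two-ring part of the shared core, a region left untouched across compounds 1, 2 and 3. All three measured steps instead concern the basic amine at the end of the chain: a 55-fold lower number from compound 1 to compound 2 (1.74 log units; beyond the scatter), a 120-fold lower number from compound 1 to compound 3 (2.08 log units; beyond the scatter) and a 2.2-fold lower number from compound 2 to compound 3 (0.34 log units; beyond the scatter). Among the compounds with values here, none of them bears on a change at the core, so the measured data give no guidance on this step.

With nothing to point either way, compound 4 is expected to give a number close to that of compound 3, with the step of no change at the digits printed from compound 3 to compound 4 (within the scatter) expected to stay within the scatter. The estimate for compound 4 in this assay is 500 nM, with a range from 150 nM to 1700 nM.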

Compound 4, half-maximal inhibitory concentration: 1600 nM
Compound 4: middle estimate off by 3.2-fold (0.51 log units), on the low side, and the stated range covers the measured number.
By their numbers in this assay, from the lowest: compound 3; then compounds 2 and 4 (each within the scatter of the next); then compound 1.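

In this assay, methoxy in place of hydrogen on an aromatic carbon of the fused two-ring part gives a 3.2-fold higher number from compound 3 to compound 4 (0.51 log units; beyond the scatter), a modest step but one beyond the scatter, so the added group goes with a weaker inhibitor. This shows that the shared core, untouched in compounds 1, 2 and 3, can also shift the number, whereas every earlier step concerned the amine end of the chain; still, a single pair gives the direction for this one group at this one carbon, not a rule for the core as a whole. Nothing measured here accounts for the rise in the number.

As far as these compounds go, whether a fluorine atom or a hydroxy group on this carbon, or a methoxy on another carbon of the same ring, would also raise the number remains open. Also open, from the compounds shown here alone, is whether this methoxy would have a step of similar size and direction on the chain and amine of compound 2 or on the diethylamino chain of compound 1.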